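The source may report more compounds than this note shows. Statements on the series, on what has been measured and on what is new or still open speak of the compounds shown alone.

Measured so far in an assay on isolated protein for binding affinity to adenosine receptor A1 (Rattus norvegicus); on this read-out higher numbers stand for weaker inhibition and lower numbers for stronger inhibition:
- compound 1, `Cn1c(=O)c2nc(-c3cccc(F)c3)[nH]c2n(C)c1=O`: compound 1 gives 2.4 nM
- compound 2, `Cc1ccc(-c2nc3c(=O)n(C)c(=O)n(C)c3[nH]2)cc1`: compound 2 gives 0.513 nM
- compound 3, `Cc1cccc(-c2nc3c(=O)n(C)c(=O)n(C)c3[nH]2)c1`: compound 3 gives 5.37 nM

Compound 2 stands lowest of the three in this assay; the nearest is compound 1, the furthest compound 3, both gaps beyond the scatter. Compounds 2 and 3 are built from the same atoms joined differently; the difference between the two cores is not broken down here.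

One change is seen once in measured pairs: from compound 3 to compound 1, (fluoro in place of methyl on an aromatic carbon). In this assay this gave a 2.2-fold lower number from compound 3 to compound 1 (0.35 log units; beyond the scatter).

Compound 4, `Cn1c(=O)c2nc(-c3ccc(F)cc3)[nH]c2n(C)c1=O`, is not yet measured. It stands to compound 2 as compound 1 stands to compound 3: fluoro in place of methyl on an aromatic carbon. The change is of the same kind, not the same, since the place differs: in the measured pair the exchanged group sits meta to a large group, in the new pair para to a large group.

For compound 4 in this assay the step is expected to be a 1.5-fold lower number from compound 2 to compound 4 (0.17 log units; within the scatter), resting on the measured pair, where the number fell by a 2.2-fold lower number from compound 3 to compound 1 (0.35 log units; beyond the scatter), and on compound 2 already giving 0.513 nM; the different place around the exchange leaves the direction uncertain, so the range is kept wide. Compound 4 is estimated at 0.35 nM, between 0.1 nM and 1.2 nM.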

Compound 4, inhibition constant: 1.82 nM
The estimate for compound 4 lay 5.2-fold (0.72 log units) below the measured number, and the stated range ends below it.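

In this assay, fluoro in place of methyl on an aromatic carbon, para to a large group, gave a 3.5-fold higher number from compound 2 to compound 4 (0.55 log units; beyond the scatter). Set beside the earlier pair, the same exchange does not carry over from one core to the other in either size or direction: the same change on two cores in this assay, a 2.2-fold lower number (0.35 log units; beyond the scatter) from compound 3 to compound 1 and a 3.5-fold higher number (0.55 log units; beyond the scatter) from compound 2 to compound 4, 7.9-fold (0.90 log units) apart, beyond the scatter of two such steps. A step read on one of these pairs is therefore no safe guide to the other, but two pairs do not show whether the place of the exchange on the aromatic ring alone decides the outcome, nor do they give a cause for the opposite directions or a rule for any further core in the series.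

The compounds shown leave open how other groups at the same places on the aromatic ring would compare with methyl and fluoro, for instance chloro, methoxy, trifluoromethyl, an amine or a carboxylic acid. Also open, from the compounds shown here alone, is whether the exchange would keep either direction on the shared core if a longer chain stood in place of the two methyl groups that all the compounds carry away from the aromatic ring.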